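Cyano for fluoro: the cytotoxicity of compound 4 awaited

This account rests on a few compounds, and the source may have more. Where it says the series, first, only, none or still open, it means among the compounds named here.

Of the compounds shown here, three on one shared core have so far been tested in an ADME assay on J774 cells (Mus musculus) for cytotoxicity, read by MTT assay, with a stated time of 48 h, tested at 50 ug/mL; on this read-out lower numbers stand for a stronger effect and higher numbers for a weaker effect at the one concentration tested. Compound 1 `O=C(N/N=C/c1ccccc1F)c1cnccn1` gives 100%, compound 3 `O=C(N/N=C/c1cccc(O)c1)c1cnccn1` gives 100%, and compound 2 `O=C(N/N=C/c1ccc(F)cc1)c1cnccn1` gives 78%, the lowest of the three numbers and beyond the scatter from each of the other two. Compound 4 `N#Cc1ccc(/C=N/NC(=O)c2cnccn2)cc1` has not yet been measured; it differs from compound 2 by cyano in place of fluoro on an aromatic carbon, the entering group sitting on an aromatic carbon of a six-membered aromatic ring of carbon only, para to a large group. Going by the values given here, no measured pair shows what this exchange does in this assay. The step is expected to be a number 12 percentage points higher from compound 2 to compound 4 (beyond the scatter), a modest rise close to the usual scatter. Compound 4 is therefore estimated to give 90%, within a range from 70% to 105%.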

Compound 4, a percentage reported as activity, at one concentration (the size of the read-out at that concentration, not a potency): 100%
Compound 4: the middle estimate sits 10 percentage points below what was measured, and the stated range covers the measured number.
By their numbers in this assay, from the lowest: compound 2; then compounds 1, 3 and 4 (each within the scatter of the next).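

In this assay, cyano in place of fluoro on this aromatic carbon, para to a large group, gives a number 22 percentage points higher from compound 2 to compound 4 (beyond the scatter), the first step read on the shared core. The number at this position therefore depends on the group carried there, since this single exchange separates the two compounds beyond the scatter. Nothing measured here accounts for the size of this step. On these data alone, it remains open whether an amine, a carboxylic acid or a methoxy group on the same carbon would give a number nearer compound 2 or compound 4.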